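Amide side-chain change on the ketone-bearing core

The compounds below may be only part of what the source reports. "The series", "measured", "known", "first", "only" and "open" are said of these compounds alone.

Going by the values given here, compound 1 `CCn1c(C(=O)NCCN)ccc1C(CC)(CC)c1ccc(OCC(=O)C(C)(C)C)c(C)c1` gives 120 nM in an assay on HL-60 cells for agonist activity at vitamin D3 receptor (Homo sapiens), read by microscopy, with a stated time of 96 h (on this read-out higher numbers stand for an effect only at larger amounts of compound and lower numbers for an effect already at smaller amounts), the highest of the three numbers so far; compound 2 `CCn1c(C(=O)NCCN)ccc1C(CC)(CC)c1ccc(OCC(O)C(C)(C)C)c(C)c1` gives 10 nM and compound 3 `CCn1c(C(=O)N(CCC#N)CCC#N)ccc1C(CC)(CC)c1ccc(OCC(O)C(C)(C)C)c(C)c1` gives 97 nM. Compound 4 `CC[C@@H](C)[C@H](NC(=O)c1ccc(C(CC)(CC)c2ccc(OCC(=O)C(C)(C)C)c(C)c2)n1CC)C(=O)O` differs from compound 1 only at the amide-type nitrogen: 1-carboxy-2-methylbutyl in place of 2-aminoethyl on an amide-type nitrogen. The step at the oxygen-bound chain carbon, a 12-fold lower number from compound 1 to compound 2 (1.08 log units; beyond the scatter), does not touch this position. Among the compounds with values here, the single measured change at the amide nitrogen, a 9.7-fold higher number from compound 2 to compound 3 (0.99 log units; beyond the scatter), moved to a higher number, and it is the only guide here; a shift of similar direction but uncertain size is expected. Compound 4 is therefore estimated at 250 nM, within a range from 60 nM to 1000 nM. This estimate means an expected 2.1-fold higher number from compound 1 to compound 4 (0.32 log units; beyond the scatter).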

Compound 4, half-maximal effective concentration: 10 nM
Estimate against measurement, compound 4: 25-fold (1.40 log units) above, and the stated range ends above it.
By their numbers in this assay, from the lowest: compounds 2 and 4 (each within the scatter of the next); then compounds 3 and 1 (each within the scatter of the next).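

On the ketone-bearing core, the amide-type nitrogen is not a position where enlargement only raises the number: 1-carboxy-2-methylbutyl in place of 2-aminoethyl gives a 12-fold lower number from compound 1 to compound 4 (1.08 log units; beyond the scatter). Going by these compounds alone, the only earlier change on this nitrogen, on the hydroxyl-bearing core, went the other way, with a 9.7-fold higher number from compound 2 to compound 3 (0.99 log units; beyond the scatter), so direction here depends on the group entering, the core, or both. No available evidence accounts for this step.

Open, on these data alone, is whether a carboxymethyl group, lacking the branched chain, would match compound 4. Also open, as far as these compounds go, is how 1-carboxy-2-methylbutyl behaves on the hydroxyl-bearing core of compound 2.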